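A Bromophenyl Replacement on the Amine Nitrogen

This account rests on a few compounds, and the source may have more. Where it says the series, first, only, none or still open, it means among the compounds named here.

Of the compounds shown here, three sharing one core have been measured in a functional assay, with a stated time of 6 min; a lower number here means a stronger inhibitor, a higher number a weaker inhibitor. Compound 1, `Fc1cccc(F)c1NCn1nc(-c2ccc3c(c2)OCCO3)oc1=S`, gives 3320 nM, the lowest of the three numbers. Compound 2, `FC(F)(F)c1ccccc1NCn1nc(-c2ccc3c(c2)OCCO3)oc1=S`, gives 9220 nM, and compound 3, `FC(F)(F)c1cccc(NCn2nc(-c3ccc4c(c3)OCCO4)oc2=S)c1`, gives 7620 nM. Both gaps from compound 1 lie beyond the usual scatter, so compound 1 stands as the strongest inhibitor of the three in this assay.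

Compound 4, `S=c1oc(-c2ccc3c(c2)OCCO3)nn1CNc1ccc(Br)cc1`, has not yet been measured. It differs from compound 1 in one place: 4-bromophenyl in place of 2,6-difluorophenyl on an amine nitrogen. Among the measured compounds shown here, no measured pair shows this exact change, so its effect is uncertain. Compounds 2 and 3 show that other aryl groups on the same amine nitrogen give weaker inhibition than compound 1, and a comparable outcome is expected here, with a modest weakening from compound 1 to compound 4 of a 1.7-fold higher number from compound 1 to compound 4 (0.22 log units; within the scatter). Compound 4 is thus estimated at 5500 nM, with a range from 2000 nM to 15000 nM.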

Compound 4, half-maximal inhibitory concentration: 14700 nM
Compound 4: middle estimate off by 2.7-fold (0.43 log units), on the low side, within the range that was stated.
By their numbers in this assay, from the lowest: compound 1; then compounds 3, 2 and 4 (each within the scatter of the next).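

In this assay, among the compounds shown here, 4-bromophenyl in place of 2,6-difluorophenyl on the amine nitrogen gives a 4.4-fold higher number from compound 1 to compound 4 (0.65 log units; beyond the scatter), and this is the first step at this position that can be read in one place. It shows that the position responds to a change of aryl group: both groups are a six-membered aromatic ring of carbon only, with no hydrogen-bond donors or acceptors and no net charge, yet the step lies beyond the scatter. Nothing among the data shown explains this step.

For the compounds shown here, the single swap removes both fluorines and brings in the bromine at once, so the share of each in the step remains open. On these data alone, how an unsubstituted phenyl ring, a pyridine ring or a chlorine-bearing phenyl ring on the same nitrogen would compare also remains open.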